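The source may hold more compounds than are shown below. What is called first, only, known or untested is meant among the compounds shown, and "the series" means these compounds.

Measured so far:
compound 1 `CCn1c(/C=C2/C(=O)Nc3ccccc32)nc2ccccc21`: > 50000 nM (a limit)
compound 2 `Cn1c(/C=C2/C(=O)Nc3ccc(Cl)cc32)nc2ccccc21`: 43600 nM

Both compounds were tested in a functional assay on 4T1 cells (Homo sapiens) for cytotoxicity, read by MTT assay, with a stated time of 48 h; a lower number here means a stronger inhibitor, a higher number a weaker inhibitor. Compound 1 gives > 50000 nM, which is a limit of the assay and not a number. Going by the values given here, compound 2, at 43600 nM, therefore holds the only numerical value, and no measured step is available for comparison.

The next compound is compound 3 `CCn1c(/C=C2/C(=O)Nc3ccc(Cl)cc32)nc2ccccc21`, which differs from compound 2 by one change on the shared core: methyl in place of hydrogen on a saturated chain carbon bound to an aromatic nitrogen. This is methyl in place of hydrogen on a saturated chain carbon bound to an aromatic nitrogen, or methyl to ethyl when cut one bond further out. Among the compounds with values here, the series offers no measured example of this change, so the expectation starts from compound 2 at 43600 nM. No step beyond the scatter is expected in this assay, and a result reported only as a limit remains possible. The expected step of a 1.2-fold lower number from compound 2 to compound 3 (0.08 log units; within the scatter) is small. The estimate for compound 3 is 36000 nM, with an expected range of 14000 nM to 50000 nM.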

Compound 3, half-maximal inhibitory concentration: > 50000 nM
Compound 3 gave a limit, no number; the forecaster's own chance of this, stated with the estimate: 30%; middle value at least 1.3-fold (0.14 log units) from the limit.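

In this assay, the saturated chain carbon bound to an aromatic nitrogen now has its first measured change: methyl in place of hydrogen, or methyl to ethyl when cut one bond further out, gives an at least 1.1-fold higher number from compound 2 to compound 3 (0.05 log units; that floor lies within the scatter). The value of compound 3 is a limit and not a number; it fixes only a floor for the step, and the true size may be larger, while the floor as printed shows no difference beyond the scatter. What the change does show is that the ethyl compound offers no readable gain over the methyl compound, and the series now sits mostly at one ceiling: the limit of > 50000 nM in this assay, at which 2 of the 3 values shown sit.

Going by these compounds, the step for chloro in place of hydrogen on an aromatic carbon, from compound 1 to compound 3, cannot be read, since both of its ends are limits, and the contribution of the chloro group stays open. Also open, on these data alone, is whether a longer chain, or an amine or a carboxylic acid carried on that chain, would give a readable number in this assay.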